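Limit values across the series, one benzofuran step ahead

The compounds below may be only part of what the source reports. "The series", "measured", "known", "first", "only" and "open" are said of these compounds alone.

Measured so far in a functional assay on K562 cells (Homo sapiens), read by MTT assay, with a stated time of 72 h; a lower number here means a stronger inhibitor, a higher number a weaker inhibitor:
- compound 1 `Nc1nc(N)c2c(-c3cccs3)cn([C@@H]3O[C@H](CO)[C@@H](O)[C@H]3O)c2n1` gives > 20000 nM (a limit)
- compound 2 `Cc1nc(N)c2c(-c3ccoc3)cn([C@@H]3O[C@H](CO)[C@@H](O)[C@H]3O)c2n1` gives > 20000 nM (a limit)
- compound 3 `Cc1nc(N)c2c(-c3cccs3)cn([C@@H]3O[C@H](CO)[C@@H](O)[C@H]3O)c2n1` gives > 20000 nM (a limit)

Compound 3 stands at > 20000 nM as a limit and not a number, so no measured value marks its place in the series.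

Compound 4 `Cc1nc(N)c2c(-c3cc4ccccc4o3)cn([C@@H]3O[C@H](CO)[C@@H](O)[C@H]3O)c2n1` carries 1-benzofuran-2-yl in place of thiophen-2-yl on an aromatic carbon. Going by the values given here, two measured steps bear on this change (a step that the two limits leave unreadable from compound 2 to compound 3 and a step that the two limits leave unreadable from compound 1 to compound 3), and neither has a readable size. The first of them exchanges the group at the same place; the second changes a different one. The expectation therefore rests only on the limit of > 20000 nM in this assay, at which 3 of the 3 values shown sit, as the pattern so far. No step beyond the scatter is expected (a number no higher from compound 3 to compound 4 (the limit leaves the size open)) and this assay will probably report a limit again. The estimate for compound 4 is 20000 nM with 6000 nM to 30000 nM as its expected range.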

Compound 4, half-maximal inhibitory concentration: 4990 nM
Compound 4: middle estimate off by 4.0-fold (0.60 log units), on the high side, outside the stated range (below it).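

Going by these compounds alone, with 1-benzofuran-2-yl on this aromatic carbon, this assay gives the first readable steps, an at least 4.0-fold lower number from compound 3 to compound 4 (0.60 log units; beyond the scatter) and an at least 4.0-fold lower number from compound 2 to compound 4 (0.60 log units; beyond the scatter) for the exchange of the earlier five-membered groups. The earlier steps shown here cannot be read, so this position is now the only place where a change is seen to move the result. The gain rests on a single compound, and the series otherwise stays at its limit: the limit of > 20000 nM in this assay, at which 3 of the 4 values shown sit.

The change from thiophen-2-yl to 1-benzofuran-2-yl swaps sulfur for oxygen and adds a six-membered aromatic ring of carbon only, and the compounds shown do not separate these two differences. From the compounds shown here alone, a 1-benzothiophen-2-yl group would keep the added ring with the sulfur, and the effect of amino in place of methyl on the core of compound 4 also remains open.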